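Efficacy at the Amide Side Chain: Toward a Hydroxylated Analogue

The source may report more compounds than this note shows. Statements on the series, on what has been measured and on what is new or still open speak of the compounds shown alone.

Measured compounds:
compound 1, `C[C@@H](NC(=O)c1ccc(C#Cc2cccc(F)c2)cn1)C(C)(C)C`, gives 31.2% in an ADME assay on HEK293 cells for agonist activity at metabotropic glutamate receptor 5 (Rattus norvegicus), read by fluorescence and calcium flux; a lower number here means a smaller maximal response, a higher number a larger maximal response
compound 2, `CC(C)[C@@H](C)NC(=O)c1ccc(C#Cc2cccc(F)c2)cn1`, gives 22.5% in this assay
compound 3, `CC(C)(C)CNC(=O)c1ccc(C#Cc2cccc(F)c2)cn1`, gives 9.5% in this assay

Compound 3 stands lowest of the three in this assay. The step of a number 21.7 percentage points lower from compound 1 to compound 3 (beyond the scatter) and the step of a number 13 percentage points lower from compound 2 to compound 3 (beyond the scatter) both reach beyond the scatter, whereas the step of a number 8.7 percentage points lower from compound 1 to compound 2 (within the scatter) does not. Compound 4, `CC(C)(CO)NC(=O)c1ccc(C#Cc2cccc(F)c2)cn1`, has not yet been measured. The change from compound 3 is 1-(hydroxymethyl)-1-methylethyl in place of neopentyl on an amide-type nitrogen. Among the measured compounds shown here, no measured step introduces a hydroxyl group, so the two steps that bear on it are only those ending at compound 3: the step of a number 21.7 percentage points lower from compound 1 to compound 3 (beyond the scatter) and the step of a number 13 percentage points lower from compound 2 to compound 3 (beyond the scatter) show that removing a methyl from the carbon bound to the amide nitrogen lowered the maximal response by a modest amount. Compound 4 again carries a fully substituted carbon on the amide nitrogen, so a modest rise in this assay is expected, with the hydroxyl group an unknown. For compound 4 a value of 20% is estimated, between 5% and 40%, meaning an expected step of a number 10.5 percentage points higher from compound 3 to compound 4 (beyond the scatter).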

Compound 4, largest response reached (reported as efficacy), in percent of the reference or control that the assay uses: 9.3%
Compound 4: the middle estimate sits 10.7 percentage points above what was measured; low and high end bracket the measured number.
By their numbers in this assay, from the lowest: compounds 4 and 3 (each within the scatter of the next); then compounds 2 and 1 (each within the scatter of the next).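

In this assay, putting 1-(hydroxymethyl)-1-methylethyl in place of neopentyl on the amide-type nitrogen gives a number 0.2 percentage points lower from compound 3 to compound 4 (within the scatter), so this exchange leaves the maximal response unresolved from that of compound 3, even though it adds a hydroxyl group and a fully substituted carbon on the nitrogen. The same group leaves compound 4 short of the two branched amides, with a number 13.2 percentage points lower from compound 2 to compound 4 (beyond the scatter) and a number 21.9 percentage points lower from compound 1 to compound 4 (beyond the scatter), which shows that a fully substituted carbon on the amide nitrogen, when it carries the hydroxymethyl arm, does not bring back the response seen with 1,2-dimethylpropyl or 1,2,2-trimethylpropyl. Nothing available explains this result.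

The compounds shown leave open whether the hydroxyl group cancels a gain from the fully substituted carbon or whether that carbon brings no gain at all, a question that a plain tert-butyl group on the same nitrogen would address. They also leave open whether an aminomethyl or methoxymethyl arm in place of the hydroxymethyl would read any differently.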